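Ester Group Exchange and Tolerated Concentration on Liver Cells

The source may hold more compounds than are shown below. What is called first, only, known or untested is meant among the compounds shown, and "the series" means these compounds.

Compounds measured so far:
compound 1, `CC(=O)OCCc1c(-c2ccccc2Cl)c2cc(Cl)ccc2[nH]c1=O`: 27000 nM
compound 2, `CC(=O)NCC(=O)OCCc1c(-c2ccccc2Cl)c2cc(Cl)ccc2[nH]c1=O`: 110000 nM
compound 3, `O=C(OCCc1c(-c2ccccc2Cl)c2cc(Cl)ccc2[nH]c1=O)c1cccs1`: > 1700000 nM

The three compounds share one core and differ only in the group on the carbonyl carbon of the ester. In an ADME assay on HepG2 2.2.15 cells (Homo sapiens) for cytotoxicity (a lower number here means that less compound is tolerated, a higher number that more compound is tolerated), compound 1 gives 27000 nM. Compound 2 gives 110000 nM, a change of a 4.1-fold higher number from compound 1 to compound 2 (0.61 log units; beyond the scatter). For compound 3 the assay reports no number but only a limit, > 1700000 nM, which is the limit of > 1700000 nM in this assay, at which 1 of the 3 values shown sits. On these data alone, compound 3 therefore stands at the top of the numbers so far, and its true value is unknown beyond that limit.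

Compound 4, `COc1ccc(/C=C/C(=O)OCCc2c(-c3ccccc3Cl)c3cc(Cl)ccc3[nH]c2=O)cc1`, again exchanges the group on the carbonyl carbon: 2-(4-methoxyphenyl)ethenyl in place of thiophen-2-yl on a carbonyl carbon. Among the compounds with values here, two measured steps bear on such an exchange at this position, an at least 62-fold higher number from compound 1 to compound 3 (1.79 log units; beyond the scatter) and an at least 15-fold higher number from compound 2 to compound 3 (1.18 log units; beyond the scatter), both large and both toward a higher number. Compound 4 is therefore expected to remain at or near the limit, with a step of a number no higher from compound 3 to compound 4 (the limit leaves the size open). The estimate for compound 4 is 1700000 nM, in the range from 300000 nM to 6000000 nM.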

Compound 4, half-maximal cytotoxic concentration: > 1200000 nM
Compound 4: only a limit was reported; the forecaster's own chance of this, stated with the estimate: 60%; the middle value is on the limit's open side.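

Compound 4 brings 2-(4-methoxyphenyl)ethenyl, with 10 heavy atoms and a six-membered aromatic ring, to the carbonyl carbon, and in this assay its reading is again only a limit: the limit of > 1200000 nM in this assay, at which 1 of the 4 values shown sits.

A high tolerated concentration is therefore not tied to thiophen-2-yl alone, as the comparison with the smaller groups shows: an at least 10-fold higher number from compound 2 to compound 4 (1.03 log units; beyond the scatter), and an at least 44-fold higher number from compound 1 to compound 4 (1.64 log units; beyond the scatter). Among these four compounds, the two esters with an aromatic ring on the carbonyl carbon give limits, whereas methyl and acetamidomethyl give measured numbers.

On these data alone, the step from compound 3 to compound 4 cannot be read, so it remains open which of these two groups is better tolerated. Also open, as far as these compounds go, is how an amine, a carboxylic acid or a longer saturated chain on the carbonyl carbon would read in this assay.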